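The source may report more compounds than this note shows. Statements on the series, on what has been measured and on what is new or still open speak of the compounds shown alone.

Of the compounds shown here, three built on one shared core have been measured in an assay for displacement of a labelled ligand from melanin-concentrating hormone receptor 1 (Homo sapiens), read by fluorescence; on this read-out lower numbers stand for stronger inhibition and higher numbers for weaker inhibition. Compound 1 `CC(=O)Nc1cccc(C2CCN(CCCn3c(-c4cccc(Cl)c4)nc4ccccc43)CC2)c1` gives 5 nM. Compound 2 `CCc1ccc(-c2nc3ccccc3n2CCCN2CCC(c3cccc(NC(C)=O)c3)CC2)cc1` gives 32 nM in this assay, and compound 3 `CC(=O)Nc1cccc(C2CCN(CCCn3c(-c4ccc(C#N)cc4)nc4ccccc43)CC2)c1` gives 16 nM. Among these three numbers compound 3 stands second highest: its nearest neighbour is compound 2, the step of a 2.0-fold lower number from compound 2 to compound 3 (0.30 log units; within the scatter) lying within the scatter, while its furthest is compound 1, the step of a 3.2-fold higher number from compound 1 to compound 3 (0.51 log units; beyond the scatter) lying beyond it.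

Compound 4 `CC(=O)Nc1cccc(C2CCN(CCCn3c(-c4ccc(Cl)c(Cl)c4)nc4ccccc43)CC2)c1` has not yet been measured. It differs from compound 3 in one place: 3,4-dichlorophenyl in place of 4-cyanophenyl on an aromatic carbon. Among the measured compounds shown here, two measured steps bear on this change. The step of a 3.2-fold higher number from compound 1 to compound 3 (0.51 log units; beyond the scatter) shows that a 3-chlorophenyl ring gave a lower number than a 4-cyanophenyl ring, and the step of a 6.4-fold higher number from compound 1 to compound 2 (0.81 log units; beyond the scatter) shows that a 4-ethylphenyl ring gave a higher number than the 3-chlorophenyl ring. Compound 4 keeps the chlorine that compound 1 carries and adds a second one. On that basis the step of a 2.0-fold lower number from compound 3 to compound 4 (0.30 log units; within the scatter) is expected to be small, toward a lower number, and within the scatter. Compound 4 is therefore estimated at 8 nM, in a range from 3 nM to 25 nM.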

Compound 4, half-maximal inhibitory concentration: 24 nM
The estimate for compound 4 lay 3.0-fold (0.48 log units) below the measured number; low and high end bracket the measured number.
By their numbers in this assay, from the lowest: compound 1; then compounds 3, 4 and 2 (each within the scatter of the next).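

In this assay, chloro in place of hydrogen on the 3-chlorophenyl ring gives a 4.8-fold higher number from compound 1 to compound 4 (0.68 log units; beyond the scatter), so a second chlorine does not keep the number of compound 1, and this step lies beyond the scatter. The 3,4-dichlorophenyl ring cannot be told apart from the 4-cyanophenyl ring, a 1.5-fold higher number from compound 3 to compound 4 (0.18 log units; within the scatter), or from the 4-ethylphenyl ring, a 1.3-fold lower number from compound 2 to compound 4 (0.12 log units; within the scatter), both steps lying within the scatter; at this carbon between two ring nitrogen atoms, compounds 2, 3 and 4 therefore form one group, and only compound 1, with its 3-chlorophenyl ring, stands apart from them, with the lowest number. Nothing measured here accounts for the loss that comes with the added chlorine, or for the closeness of the three rings.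

The compounds shown leave open how an unsubstituted phenyl ring would compare with the 3-chlorophenyl ring of compound 1, and so whether the single chlorine lowers the number at all. They also leave open how a ring bearing a methoxy group or an amine, or a pyridine ring, would stand at this place on the shared core.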